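The source may hold more compounds than are shown below. What is called first, only, known or untested is meant among the compounds shown, and "the series" means these compounds.

In a physicochemical assay for solubility, at pH 4 (on this read-out higher numbers stand for higher solubility and lower numbers for lower solubility), compound 2 (`CC[C@H]1OC(=O)[C@H](C)[C@@H](O[C@H]2C[C@@](C)(OC)[C@@H](O)[C@H](C)O2)[C@H](C)[C@@H](O[C@@H]2O[C@H](C)C[C@H](N(C)C)[C@H]2OCCCNCc2ccnc3ccccc23)[C@](C)(O)C[C@@H](C)CN(C)[C@H](C)[C@@H](O)[C@]1(C)O`) gives > 10000 ug/mL as a limit of the assay and not a number. Compound 3 (`CC[C@H]1OC(=O)[C@H](C)[C@@H](O[C@H]2C[C@@](C)(OC)[C@@H](O)[C@H](C)O2)[C@H](C)[C@@H](O[C@@H]2O[C@H](C)C[C@H](N(C)C)[C@H]2OCCCN(C)Cc2ccnc3ccccc23)[C@](C)(O)C[C@@H](C)CN(C)[C@H](C)[C@@H](O)[C@]1(C)O`) gives > 10000 ug/mL as a limit too. Compound 1 (`CC[C@H]1OC(=O)[C@H](C)[C@@H](O)[C@H](C)[C@@H](O[C@@H]2O[C@H](C)C[C@H](N(C)C)[C@H]2OCCCNc2ccnc3cc(Cl)ccc23)[C@](C)(O)C[C@@H](C)CN(C)[C@H](C)[C@@H](O)[C@]1(C)O`) gives > 10000 ug/mL as a limit as well. Compound 2 therefore has no exact number to start from, and the data so far amount to the limit of > 10000 ug/mL in this assay, at which 3 of the 3 values shown sit, with nothing finer to read. Compound 4 (`CC[C@H]1OC(=O)[C@H](C)[C@@H](O)[C@H](C)[C@@H](O[C@@H]2O[C@H](C)C[C@H](N(C)C)[C@H]2OCCCNCc2ccnc3ccccc23)[C@](C)(O)C[C@@H](C)CN(C)[C@H](C)[C@@H](O)[C@]1(C)O`) has not yet been measured. It differs from compound 2 as follows: hydrogen in place of 5-hydroxy-4-methoxy-4,6-dimethyloxan-2-yl on an oxygen on a saturated carbon and, cut one bond further out, (5-hydroxy-4-methoxy-4,6-dimethyloxan-2-yl)oxy gives way to hydroxy. For the measured compounds named here, the only measured step, methyl in place of hydrogen on an amine nitrogen, is a step that the two limits leave unreadable from compound 2 to compound 3 and so offers no size to carry over, and it is a different change. Compound 1 also carries hydrogen on that oxygen, though it differs from compound 4 elsewhere. Compound 1 still shows > 10000 ug/mL as a limit. No step beyond the scatter is therefore expected in either direction in this assay on present evidence. The expected change is a number no higher from compound 2 to compound 4 (the limit leaves the size open) and it should not be read as a real shift. For compound 4 the estimate is 10000 ug/mL with an expected range from 5000 ug/mL to 20000 ug/mL. There is a strong chance that compound 4 will again give only a limit.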

Compound 4, solubility: > 10000 ug/mL
Compound 4: only a limit was reported; the forecaster's own chance of this, stated with the estimate: 85%; the middle value lies on the limit itself.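

In this assay compound 4 gives > 10000 ug/mL, a limit of the assay and not a number. Neither the step from compound 2 to compound 4 nor the step from compound 1 to compound 4 can be read: all three compounds show only limits. The compounds shown leave open how far their solubilities actually differ, and whether either change shifts them at all.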